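The source may hold more compounds than are shown below. What is called first, only, known or untested is meant among the compounds shown, and "the series" means these compounds.

Measured compounds:
compound 1, `CC/N=C(/N)Nc1nc(-c2ccc(OC)cc2)c(-c2ccc(OC)cc2)s1`: in a functional assay with Oryctolagus cuniculus as the target (a lower number here means a stronger inhibitor, a higher number a weaker inhibitor), compound 1 gives > 100 nM, which is a limit of the assay rather than a number.
compound 2, `COc1ccc(-c2nc(/N=C(\N)NC(C)C)sc2-c2ccc(OC)cc2)cc1`: in this assay compound 2 gives > 100 nM, again a limit of the assay.
compound 3, `COc1ccc(-c2nc(CN(C)C)sc2-c2ccc(OC)cc2)cc1`: in this assay compound 3 gives 96 nM.

Compound 2 thus stands at the limit, and so does compound 1 (the limit of > 100 nM in this assay, at which 2 of the 3 values shown sit); only compound 3 carries a number. The step that the two limits leave unreadable from compound 1 to compound 2 is therefore unreadable. For the measured compounds named here, the steps that bear on compound 4 are an at least 1.0-fold lower number from compound 2 to compound 3 (0.01 log units; that floor lies within the scatter) and an at least 1.0-fold lower number from compound 1 to compound 3 (0.01 log units; that floor lies within the scatter), both of which replace the larger group on the aromatic carbon with a group of 4 heavy atoms and both of which only set a floor that lies within the scatter. Compound 4, `COc1ccc(-c2nc(CN)sc2-c2ccc(OC)cc2)cc1`, differs from compound 2 in the same place: a group of 2 heavy atoms (1 carbon, 1 nitrogen; no ring) in place of a group of 7 heavy atoms (4 carbon, 3 nitrogen; no ring), on an aromatic carbon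

On this evidence the change from the group of 7 heavy atoms to a smaller amine-bearing group gives no readable step. Compound 4 is therefore expected to land near the limit, with an estimated 90 nM, between 30 nM and 300 nM, which means an expected step of an at least 1.1-fold lower number from compound 2 to compound 4 (0.04 log units; that floor lies within the scatter).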

Compound 4, half-maximal inhibitory concentration: > 100 nM
Compound 4: a limit, no number; the forecaster's own chance of this, stated with the estimate: 45%; at least 1.1-fold (0.04 log units) between middle value and limit.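

Compound 4 adds a direct comparison at this position, on the saturated chain carbon bound to an aromatic carbon: amino in place of the dimethylamino of compound 3. In this assay this change gives an at least 1.0-fold higher number from compound 3 to compound 4 (0.01 log units; that floor lies within the scatter), so it sets only a floor within the scatter and shows no readable effect of removing the two methyl groups from the nitrogen. The steps from compound 2 to compound 4 and from compound 1 to compound 4 cannot be read, and the series now offers a single numerical value: the limit of > 100 nM in this assay, at which 3 of the 4 values shown sit.

The compounds shown leave open how large the difference between compound 3 and compound 4 really is. They also leave open whether methylamino on the same chain carbon, or a longer chain carrying an amine, would give a value that is a number rather than a limit.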